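Swapping the para group on the urea-bearing ring

The source may report more compounds than this note shows. Statements on the series, on what has been measured and on what is new or still open speak of the compounds shown alone.

Three compounds share one core and differ only at a single spot on the pyridine ring. Compound 1 `CC(C)c1ccc(NC(=O)N2CCN(c3ncccc3Cl)CC2)cc1` carries a chloro there and, in a functional assay on HEK293 cells for antagonist activity at transient receptor potential cation channel subfamily V member 1 (Rattus norvegicus) (on this read-out higher numbers stand for weaker inhibition and lower numbers for stronger inhibition), compound 1 gives 11.5 nM, the lowest of the three numbers shown. Compound 2 `Cc1cccnc1N1CCN(C(=O)Nc2ccc(C(C)C)cc2)CC1` has a methyl in that place and gives 25.3 nM; compound 3 `CC(C)c1ccc(NC(=O)N2CCN(c3ncccc3C=O)CC2)cc1` has a formyl and gives 201 nM. The steps are a 2.2-fold higher number from compound 1 to compound 2 (0.34 log units; beyond the scatter), a 17-fold higher number from compound 1 to compound 3 (1.24 log units; beyond the scatter) and a 7.9-fold higher number from compound 2 to compound 3 (0.90 log units; beyond the scatter).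

Compound 4 `O=C(Nc1ccc(Br)cc1)N1CCN(c2ncccc2Cl)CC1` keeps the chloro of compound 1 and changes the other end instead: bromo in place of isopropyl on an aromatic carbon. Going by the values given here, none of the measured steps touches this position; all three concern the pyridine substituent, so they give no direct guide to what a bromo does in place of an isopropyl. What they do show is that a small change at one aromatic position can move this read-out by a modest or large amount, so some shift should be allowed for here too.

With no closer comparison, compound 4 is expected to sit somewhat weaker than compound 1, with an estimated step of a 3.0-fold higher number from compound 1 to compound 4 (0.48 log units; beyond the scatter). The estimated value for compound 4 in this assay is 35 nM, within a range from 9 nM to 140 nM.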

Compound 4, half-maximal inhibitory concentration: 491 nM
Compound 4: the middle estimate sits 14-fold (1.15 log units) below what was measured, and the stated range ends below it.
By their numbers in this assay, from the lowest: compound 1; then compound 2; then compound 3; then compound 4.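

Keeping the chloro of compound 1 and replacing only isopropyl with bromo, on an aromatic carbon of a six-membered aromatic ring of carbon only, para to a large group, gives a 43-fold higher number from compound 1 to compound 4 (1.63 log units; beyond the scatter) in this assay. Going by these compounds alone, the earlier compounds varied only a single spot on the pyridine ring, so this is the first sign that this second position also strongly affects the read-out, with the higher number here meaning weaker inhibition. The change swaps three carbon atoms for one bromine atom and alters neither the hydrogen-bond donor and acceptor counts nor the net charge, so those counts do not separate the two compounds, and nothing available explains the size of the step.

As far as these compounds go, with only isopropyl and bromo at this position, it remains open whether a tert-butyl, a trifluoromethyl, a chloro or a methoxy group would behave more like the first or the second. From the compounds shown here alone, it is also open whether the methyl and formyl groups on the pyridine ring would keep their order relative to chloro if bromo stood in place of isopropyl.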